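This account rests on a few compounds, and the source may have more. Where it says the series, first, only, none or still open, it means among the compounds named here.

Compound 1 `Cc1cc2c(cc1C(=O)c1ccc(C(=O)OCCCOC(=O)c3ccc(C(=O)Nc4ccc5c(c4)C(C)(C)CCC5(C)C)cc3)cc1)C(C)(C)CCC2(C)C`: 49100 nM
Compound 2 `CCCC(CCC)C(=O)OCCCCOC(=O)c1ccc(C(=O)Nc2ccc3c(c2)C(C)(C)CCC3(C)C)cc1`: > 1000000 nM, a limit of the assay rather than a number.
Compound 3 `C=C(c1ccc(C(=O)OCCCOC(=O)c2ccc(C(=O)Nc3ccc4c(c3)C(C)(C)CCC4(C)C)cc2)cc1)c1cc2c(cc1C)C(C)(C)CCC2(C)C`: > 1000000 nM, again a limit rather than a number.

These three compounds were tested in a functional assay on K562 cells (Homo sapiens) for inhibition, read by MTT assay, with a stated time of 48 h; a lower number here means a stronger inhibitor, a higher number a weaker inhibitor. Only compound 1 yielded a number; compound 2 stands at the limit of > 1000000 nM in this assay, at which 2 of the 3 values shown sit. No two of the measured compounds differ in just one place, so no single step can be read from them, and nothing among them shows what a small change in the chain does.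

Compound 4 `CCCC(CCC)C(=O)OCCOC(=O)c1ccc(C(=O)Nc2ccc3c(c2)C(C)(C)CCC3(C)C)cc1` is not yet measured. It differs from compound 2 in one place: ((1-propylbutyl)carbonyl)oxy in place of 2-(((1-propylbutyl)carbonyl)oxy)ethyl on a saturated chain carbon, two bonds along the chain from an oxygen next to a carbonyl group. The rest of compound 2 is untouched. Compound 2 gave only a limit in this assay, > 1000000 nM. On that basis compound 4 is expected to remain a weak inhibitor, and the step expected from compound 2 to compound 4 is a step that the limit leaves unreadable from compound 2 to compound 4, nothing beyond the scatter. Compound 4 is therefore estimated at 1500000 nM, with a range from 300000 nM to 6000000 nM, and the assay will most likely report only a limit for it.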

Compound 4, half-maximal inhibitory concentration: 664000 nM
Compound 4: middle estimate off by 2.3-fold (0.35 log units), on the high side, and the stated range covers the measured number.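

In this assay, putting ((1-propylbutyl)carbonyl)oxy in place of 2-(((1-propylbutyl)carbonyl)oxy)ethyl on this saturated chain carbon shortens the chain and gives an at least 1.5-fold lower number from compound 2 to compound 4 (0.17 log units; that floor lies within the scatter). Compound 4 gives a real number at this position, 664000 nM, and it remains a weak inhibitor, so the shorter chain shows no gain beyond the scatter. The true size of the step cannot be read, because compound 2 carries only a limit of the assay: the limit of > 1000000 nM in this assay, at which 2 of the 4 values shown sit.

The compounds shown leave open whether an amine or a carboxylic acid at the end of this chain, in place of the ester, would move the number further. Compound 1 differs from compound 4 in more than one place, so no single change links those two values.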